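A few compounds are considered here, and "the series" means these few. Any claim that something is new, unique, unknown or untested is made for them only; others in the source may bear on it.

Compound 1 `Cc1ccc(S(=O)(=O)/N=C(/CCNC2=CC(=O)c3ccccc3C2=O)Nc2ccc(Cl)cc2)cc1` sits second highest of the three numbers in a functional assay on A549 cells (Homo sapiens) for cytotoxicity, read by MTT assay, with a stated time of 48 h (a higher number here means a weaker inhibitor, a lower number a stronger inhibitor), where compound 1 gives 29900 nM. Compound 2 `COc1ccc(N/C(CCNC2=CC(=O)c3ccccc3C2=O)=N\S(=O)(=O)c2ccc(C)cc2)c(OC)c1` gives 126000 nM, a step of a 4.2-fold higher number from compound 1 to compound 2 (0.62 log units; beyond the scatter). Compound 3 `Cc1ccc(S(=O)(=O)/N=C(/CCNC2=CC(=O)c3ccccc3C2=O)Nc2cc(F)c(F)c(F)c2)cc1` gives 10200 nM, a step of a 2.9-fold lower number from compound 1 to compound 3 (0.47 log units; beyond the scatter), and from compound 2 the step is a 12-fold lower number from compound 2 to compound 3 (1.09 log units; beyond the scatter). Compound 4 `Cc1ccc(S(=O)(=O)/N=C(/CCNC2=CC(=O)c3ccccc3C2=O)NC(C)C)cc1` differs from compound 1 by isopropyl in place of 4-chlorophenyl on an amine nitrogen. Among the compounds with values here, none of the measured steps replaces the aromatic ring with a chain, so they bear only loosely; among the aryl variants the numbers move only as far as a 12-fold lower number from compound 2 to compound 3 (1.09 log units; beyond the scatter) shows. The expected step is a 1.7-fold higher number from compound 1 to compound 4 (0.22 log units; within the scatter), a modest rise with wide uncertainty. Compound 4 is therefore estimated at 50000 nM, between 15000 nM and 160000 nM.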

Compound 4, half-maximal inhibitory concentration: 44300 nM
The estimate for compound 4 lay 1.1-fold (0.05 log units) above the measured number; the range from low to high includes it.
By their numbers in this assay, from the lowest: compound 3; then compounds 1 and 4 (each within the scatter of the next); then compound 2.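

In this assay, losing the aromatic ring at this amine nitrogen need not cost activity: isopropyl in place of 4-chlorophenyl gives a 1.5-fold higher number from compound 1 to compound 4 (0.17 log units; within the scatter) and leaves the two compounds indistinguishable. The two other aryl groups sit on opposite sides of isopropyl, with a 4.3-fold higher number from compound 3 to compound 4 (0.64 log units; beyond the scatter) and a 2.8-fold lower number from compound 2 to compound 4 (0.45 log units; beyond the scatter), so the identity of the aryl group matters more here than the presence of a ring. No measurement on hand accounts for these differences. Still open, as far as these compounds go, is whether a longer alkyl chain, a cyclohexyl group or a chain bearing an amine would track isopropyl or shift the number further.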